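The source may report more compounds than this note shows. Statements on the series, on what has been measured and on what is new or still open speak of the compounds shown alone.

Three compounds share one core and differ only in the chain hung on the sulfur. Compound 1 `CC(O)CSc1nc(NCc2ccc(-c3ccccn3)cc2)c2[nH]nc(C(C)C)c2n1` gives 62 nM in a functional assay on HT cells (Homo sapiens) for antiproliferative activity, read by fluorescence, with a stated time of 72 h; a higher number here means a weaker inhibitor of growth, a lower number a stronger inhibitor of growth. Compound 2 `CC(C)c1n[nH]c2c(NCc3ccc(-c4ccccn4)cc3)nc(SCCCO)nc12` gives 109 nM in this assay, and compound 3 `CC(=O)NCCSc1nc(NCc2ccc(-c3ccccn3)cc2)c2[nH]nc(C(C)C)c2n1` gives 71 nM. Compound 2 stands at the upper edge of this set, but the spread is narrow: the changes gave a 1.8-fold higher number from compound 1 to compound 2 (0.25 log units; within the scatter), a 1.1-fold higher number from compound 1 to compound 3 (0.06 log units; within the scatter) and a 1.5-fold lower number from compound 2 to compound 3 (0.19 log units; within the scatter), all within the scatter.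

Compound 4 `CCC(CO)Sc1nc(NCc2ccc(-c3ccccn3)cc2)c2[nH]nc(C(C)C)c2n1` has not yet been measured. It differs from compound 2 by 1-(hydroxymethyl)propyl in place of 3-hydroxypropyl on a sulfur. Every measured step here rearranges or swaps the small group on that same sulfur-bound chain, and none of them moved the number beyond the scatter. The move from compound 2 to compound 4 is another change of the same kind, so a step that stays within the scatter is expected, with no clear direction.

Compound 4 is therefore estimated at 80 nM, in a range from 35 nM to 200 nM, which means an expected step of a 1.4-fold lower number from compound 2 to compound 4 (0.13 log units; within the scatter).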

Compound 4, concentration for 50% growth inhibition: 255 nM
For compound 4 the middle estimate is 3.2-fold (0.50 log units) below the measured one, outside the stated range (above it).
By their numbers in this assay, from the lowest: compounds 1, 3 and 2 (each within the scatter of the next); then compound 4.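

The sulfur-bound chain tolerates less change than the first three compounds suggested, since in this assay the steps of a 2.3-fold higher number from compound 2 to compound 4 (0.37 log units; beyond the scatter) and a 3.6-fold higher number from compound 3 to compound 4 (0.56 log units; beyond the scatter) and a 4.1-fold higher number from compound 1 to compound 4 (0.61 log units; beyond the scatter) all lie beyond the scatter, making compound 4 the weakest inhibitor of growth of the four, though only modestly. The change from 3-hydroxypropyl to 1-(hydroxymethyl)propyl keeps the hydrogen-bond donor and acceptor counts and adds a heavy atom, 5 in place of 4, so those donor and acceptor counts alone do not separate the two chains. No measurement shown explains the weaker result.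

From the compounds shown here alone, it remains open how an amine or a carboxylic acid at the end of this chain, or a longer chain, would behave. A 1-(hydroxymethyl)ethyl chain would help separate the effect of the added carbon from that of the rearranged chain.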